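The source may hold more compounds than are shown below. What is called first, only, known or untested is meant among the compounds shown, and "the series" means these compounds.

Compound 1 `Cc1cc(Nc2nc(NCc3cc(F)cc(F)c3)nc3ccccc23)n[nH]1` gives 170 nM in an assay for inhibition of high affinity nerve growth factor receptor (Homo sapiens), read by HTRF, with a stated time of 30 min, in the presence of a further agent that is not named here; a lower number here means a stronger inhibitor, a higher number a weaker inhibitor. Among the measured compounds shown here, compound 2 `Cc1cc(Nc2nc(NCc3cc(F)c(F)c(F)c3)nc3ccccc23)n[nH]1` carries a further (fluoro in place of hydrogen on an aromatic carbon); in this assay compound 2 gives 870 nM, and the step of a 5.1-fold higher number from compound 1 to compound 2 (0.71 log units; beyond the scatter) is the only measured instance of this change. Compound 3 `Fc1ccc(CNc2nc(Nc3cc(C4CC4)[nH]n3)c3ccccc3n2)cc1` differs from compound 1 in a way that is not broken down here; in this assay compound 3 gives 40 nM. Compound 4 `Fc1ccc(CNc2nc(Nc3cc(C4CC4)[nH]n3)c3ccccc3n2)c(F)c1` is not yet measured and differs from compound 3 by fluoro in place of hydrogen on an aromatic carbon. This is the same kind of change as from compound 1 to compound 2, but not the same: there the fluoro entered ortho to two fluoro groups and para to a large group, here it enters ortho to a large group and meta to a fluoro group. For the measured compounds named here, because the one measured step of this kind is a 5.1-fold higher number from compound 1 to compound 2 (0.71 log units; beyond the scatter), some loss is expected, though with the place differing the expected step for compound 4 is a 1.9-fold higher number from compound 3 to compound 4 (0.27 log units; within the scatter). Compound 4 is expected at 75 nM, between 25 nM and 220 nM.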

Compound 4, half-maximal inhibitory concentration: 4.7 nM
The estimate for compound 4 lay 16-fold (1.20 log units) above the measured number; the whole stated range lies above it.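

In this assay, the fluoro that turns the 4-fluorobenzyl group into the 2,4-difluorobenzyl group gives an 8.5-fold lower number from compound 3 to compound 4 (0.93 log units; beyond the scatter), a gain in potency where the earlier addition of a fluoro brought a loss. A fluoro in place of a hydrogen on this aromatic ring therefore has no single effect that carries from one core to another in this series: the same change on two cores in this assay, a 5.1-fold higher number (0.71 log units; beyond the scatter) from compound 1 to compound 2 and an 8.5-fold lower number (0.93 log units; beyond the scatter) from compound 3 to compound 4, 44-fold (1.64 log units) apart, beyond the scatter of two such steps. The two steps differ both in the place of the fluoro and in the rest of the molecule, so they do not show which of these decides the direction.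

On these data alone, it remains open whether the 2,4-difluorobenzyl group would bring a similar gain on the core of compound 1. As far as these compounds go, it is also open whether a chloro or methoxy group in the same place would act as the fluoro does.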